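From a Ring-Bound Amide to an Open-Chain Acid

The compounds below may be only part of what the source reports. "The series", "measured", "known", "first", "only" and "open" are said of these compounds alone.

Among the measured compounds shown here, compound 1 `COC1CN(C(=O)/C=C/c2ccncc2-c2ccc3ccccc3c2)C1` is the only member of this small set for which a number was obtained. In an assay on a protein complex for inhibition of CDK8/Cyclin C (Homo sapiens), with a stated time of 1 h (a higher number here means a weaker inhibitor, a lower number a stronger inhibitor), compound 1 gives 42.8 nM. Two companions were also prepared but no result was reported for either: for compound 2 `O=C(/C=C/c1ccncc1-c1ccc2cccnc2c1)N1CCOCC1` the entry in this assay is "not determined" (no result reported), and for compound 3 `COC1CN(C(=O)/C=C/c2ccncc2-c2ccc(F)cc2)C1` it is "not determined" (no result reported). Compound 4 `O=C(O)CCNC(=O)/C=C/c1ccncc1-c1ccc2ccccc2c1` keeps the core of compound 1 and alters only the group on the carbonyl carbon: (2-carboxyethyl)amino in place of 3-methoxyazetidin-1-yl on a carbonyl carbon. For the measured compounds named here, no pair of measured compounds shows what such a change does here, so the expectation rests on compound 1 alone and on the size of the swap, which trades a small ring for a chain of the same heavy-atom count with more hydrogen-bond donors. Compound 4 is estimated at 110 nM in this assay, with a plausible range of 25 nM to 500 nM. The expected step of a 2.6-fold higher number from compound 1 to compound 4 (0.41 log units; beyond the scatter) is a modest weakening, not far beyond the scatter.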

Compound 4, half-maximal inhibitory concentration: 870 nM
Compound 4: the middle estimate sits 7.9-fold (0.90 log units) below what was measured, outside the stated range (above it).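

Swapping 3-methoxyazetidin-1-yl for (2-carboxyethyl)amino on a carbonyl carbon gives a 20-fold higher number from compound 1 to compound 4 (1.31 log units; beyond the scatter) in this assay and so costs a large part of the inhibition seen with compound 1. The group on this carbonyl carbon therefore matters to the read-out, and the shared core does not hold the inhibition on its own. Both groups have 6 heavy atoms, so matching that count was not enough to keep the value, and nothing measured here says why the number rises.

Compound 4 loses the ring and gains the carboxylic acid in a single change, and the compounds shown do not tell these two apart. A methyl ester in place of that carboxylic acid, or an azetidine ring carrying a carboxylic acid, would be needed to divide the step between them.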